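Working notes: carbonyl-side change from compound 2 to compound 3

A few compounds are considered here, and "the series" means these few. Any claim that something is new, unique, unknown or untested is made for them only; others in the source may bear on it.

Measured so far:
compound 1 `O=C(NC1CCN(Cc2ccc(OC3CCNCC3)c(Br)c2)CC1)c1cc2cc(Br)ccc2s1` — 86 nM
compound 2 `N#Cc1ccc2cc(C(=O)NC3CCN(Cc4ccc(OC5CCNCC5)c(Br)c4)CC3)sc2c1` — 80 nM

In an assay on HEK293 cells for displacement of a labelled ligand from Urotensin-2 receptor (Homo sapiens), read by fluorescence, with a stated time of 90 min (a higher number here means a weaker inhibitor, a lower number a stronger inhibitor), compound 2 gives 80 nM. Compound 1 gives 86 nM in this assay, and the step of a 1.1-fold lower number from compound 1 to compound 2 (0.03 log units; within the scatter) is within the scatter, so compound 2 stands at the same level as compound 1 rather than apart from it.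

Compound 3 `Cc1ccc2sc(C(=O)NC3CCN(Cc4ccc(OC5CCNCC5)c(Br)c4)CC3)cc2c1` is not yet measured. It differs from compound 2 by 5-methyl-1-benzothiophen-2-yl in place of 6-cyano-1-benzothiophen-2-yl on a carbonyl carbon. For the measured compounds named here, the only measured step that bears on this change is the one at the same place, a 1.1-fold lower number from compound 1 to compound 2 (0.03 log units; within the scatter), which swapped one group on the carbonyl carbon for another without moving the number beyond the scatter. Nothing in the two measured compounds points to a larger effect for a second swap at the same place. The step of a 1.1-fold higher number from compound 2 to compound 3 (0.03 log units; within the scatter) is therefore expected to stay within the scatter, with no direction claimed. Compound 3 is estimated at 85 nM, with a range of 40 nM to 180 nM.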

Compound 3, half-maximal inhibitory concentration: 74 nM
For compound 3 the middle estimate is 1.1-fold (0.06 log units) above the measured one, within the range that was stated.
By their numbers in this assay, from the lowest: compounds 3, 2 and 1 (each within the scatter of the next).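

In this assay, a 1.1-fold lower number from compound 2 to compound 3 (0.03 log units; within the scatter) shows that replacing 6-cyano-1-benzothiophen-2-yl with 5-methyl-1-benzothiophen-2-yl, which removes the nitrile and takes the hydrogen-bond acceptor count from 2 to 1, leaves the number within the scatter. For the compounds shown here, the bromo-to-methyl swap on an aromatic carbon gives a 1.2-fold lower number from compound 1 to compound 3 (0.07 log units; within the scatter), so the bromo, cyano and methyl compounds now form one level, with no compound among the three going against it. Nothing available explains this flat response.

Still open, as far as these compounds go, is whether a benzothiophene carrying an amine or a carboxylic acid would stay at this level. All the compounds shown keep the 1-benzothiophen-2-yl group on the carbonyl carbon, so the outcome with a plain phenyl there is also open.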